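The compounds below may be only part of what the source reports. "The series", "measured", "known", "first", "only" and "open" are said of these compounds alone.

Measured compounds in this assay:
compound 1 `COc1cc(OC)c(OC)cc1/C=C/C(=O)c1ccc(C)cc1` — 81100 nM
compound 2 `COc1cc(OC)c(-c2cc(=O)c3ccc(O)cc3o2)cc1OC` — > 150000 nM (a limit)
compound 3 `COc1cc(OC)c(OC)cc1/C=C/C(=O)c1ccc([N+](=O)[O-])cc1` — > 150000 nM (a limit)

Among the compounds with values here, in a functional assay on SW982 cells (Homo sapiens) for inhibition, read by MTT assay, with a stated time of 72 h (on this read-out lower numbers stand for stronger inhibition and higher numbers for weaker inhibition), compound 1 gives 81100 nM, the only number obtained among the three. Compound 2 gives > 150000 nM, which is a limit of the assay. Compound 3 likewise gives > 150000 nM, a limit. Two of the three values therefore sit at the limit of > 150000 nM in this assay, at which 2 of the 3 values shown sit.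

Within the data shown here, the one measured step that touches the same part of the core is an at least 1.8-fold higher number from compound 1 to compound 3 (0.26 log units; that floor lies within the scatter). Among the measured compounds shown here, its floor lies within the scatter, so it tells only that the change to the aryl ketone ring did not lead to a number below the limit.

Compound 4 `COc1cc(OC)c(OC)cc1/C=C/C(=O)c1cc(O)ccc1O` is not yet measured. It differs from compound 1 by 2,5-dihydroxyphenyl in place of 4-methylphenyl on a carbonyl carbon. For the measured compounds named here, no measured pair carries two hydroxyl groups into this ring, so the step from compound 1 offers no direct precedent; the only related step is the one to compound 3, which ended at a limit. The expectation is therefore loose: a step of a 1.8-fold lower number from compound 1 to compound 4 (0.26 log units; within the scatter) is estimated, with a real chance that compound 4 also returns only a limit. Compound 4 is expected to give about 45000 nM, within 10000 nM to 150000 nM.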

Compound 4, half-maximal inhibitory concentration: > 150000 nM
Compound 4 was reported as a limit; the forecaster's own chance of this, stated with the estimate: 25%; middle value at least 3.3-fold (0.52 log units) from the limit.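

In this assay, 2,5-dihydroxyphenyl in place of 4-methylphenyl on a carbonyl carbon gives an at least 1.8-fold higher number from compound 1 to compound 4 (0.26 log units; that floor lies within the scatter). The value of compound 4 is a limit and not a number, so this step has a floor but no size, and that floor does not separate compound 4 from compound 1 beyond the scatter. What is new is that a second replacement at this place, after the nitro group of compound 3, also gives no readable number, which leaves compound 1 as the only compound with a measured value and makes the ceiling of the assay the main constraint on reading the series: the limit of > 150000 nM in this assay, at which 3 of the 4 values shown sit.

Open, as far as these compounds go, is whether any ring on this carbonyl carbon can give a lower number than compound 1, which gives 81100 nM; a dimethylamino group, a chlorine atom or a carboxylic acid on the ring would each test this. Also open, from the compounds shown here alone, is how far compound 3 and compound 4 actually lie from compound 1, and whether either hydroxyl group alone would end at a limit.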